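The compounds below may be only part of what the source reports. "The series", "measured", "known", "first", "only" and "open" are said of these compounds alone.

In an ADME assay on BJ cells (Homo sapiens) for cytotoxicity, read by CellTiter-Glo and resazurin assay, with a stated time of 72 h (on this read-out higher numbers stand for an effect only at larger amounts of compound and lower numbers for an effect already at smaller amounts), three compounds sharing one core have been tested so far, and none has given an actual number. Compound 1 `CC(C)N(Cc1cccc(OCCCCCC(=O)O)c1)C(=O)c1ccc(-c2cccc(OCc3ccccc3)c2)cc1` reads > 26000 nM, which is a limit. Compound 2 `CC(C)N(Cc1cccc(OCCCCCC(=O)O)c1)C(=O)c1ccc(-c2ccc3c(c2)OCCO3)cc1` reads > 21900 nM, also a limit. Compound 3 `COc1cc(F)cc(-c2ccc(C(=O)N(Cc3cccc(OCCCCCC(=O)O)c3)C(C)C)cc2)c1` reads > 26000 nM, again a limit, so its place among the others cannot be ranked.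

The next compound, compound 4 `CC(C)N(Cc1cccc(OCCCCCC(=O)O)c1)C(=O)c1ccc(-c2cccc(C(F)(F)F)c2)cc1`, carries 3-(trifluoromethyl)phenyl in place of 3-fluoro-5-methoxyphenyl on an aromatic carbon.

Among the measured compounds shown here, the one measured step at this same place is a step that the two limits leave unreadable from compound 2 to compound 3, so it offers no size to carry over. Still, all three different groups tested at this place have left only limits. The closest reference is compound 3 at > 26000 nM, and the expectation starts from that limit. No step beyond the usual scatter is expected, in either direction, so the estimated step is a number no higher from compound 3 to compound 4 (the limit leaves the size open). Compound 4 is estimated at 26000 nM, with an expected range from 15000 nM to 50000 nM, and it will most likely be reported as a limit too.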

Compound 4, half-maximal effective concentration: > 26000 nM
Compound 4: a limit, no number (the forecaster's own chance of this, stated with the estimate: 85%); the middle value lies on the limit itself.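

Compound 4 gives a limit and not a number, just as compound 1, compound 2 and compound 3 do, so no step to compound 4 can be read from any of them: the limit of > 26000 nM in this assay, at which 3 of the 4 values shown sit.

The compounds shown leave open at what amount, if any, each would produce a half-maximal effect on these cells.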